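The source may hold more compounds than are shown below. What is called first, only, known or untested is meant among the compounds shown, and "the series" means these compounds.

Values from a functional assay on MCF7 cells (Homo sapiens) for cytotoxicity, read by sulforhodamine B assay, with a stated time of 48 h (on this read-out lower numbers stand for stronger inhibition of growth and higher numbers for weaker inhibition of growth), for the compounds measured so far

Compound 1 (`COc1cc(C(=O)c2ccc(OC)c(O)c2OC)cc(OC)c1O`) 1010 nM
Compound 2 (`COc1ccc(C(=O)c2cc(OC)c(OC)c(OC)c2)c(OC)c1O`) 26.4 nM
Compound 3 (`COc1ccc(C(=O)c2cc(OC)c(OC)c(OC)c2)c(OC)c1N`) 10.6 nM

Compound 3 at 10.6 nM stands lowest of the three, with compound 2 at 26.4 nM nearest and compound 1 at 1010 nM furthest off. Compound 4 (`COc1ccc(C(=O)c2cc(OC)c(OC)c(OC)c2)c(OC)c1NC(C)=O`) differs from compound 3 in one place (acetyl in place of hydrogen on a nitrogen on an aromatic ring) and the amino group becomes acetamido, that is, acetyl in place of hydrogen on a nitrogen on an aromatic ring. Among the measured compounds shown here, no measured step puts anything on this nitrogen, so the evidence is indirect. There was a 2.5-fold lower number from compound 2 to compound 3 (0.40 log units; beyond the scatter) with amino in place of hydroxy on an aromatic carbon, a modest step. There was also a 38-fold lower number from compound 1 to compound 2 (1.58 log units; beyond the scatter) with methyl in place of hydrogen on an oxygen on an aromatic ring, a large step, so one small addition can move the number far in this set, although that step went downward. With compound 3 already lowest, a moderate to large rise in this assay is expected, meaning weaker inhibition of growth, but this direction is a judgement and not a measured trend. The expected change is an 11-fold higher number from compound 3 to compound 4 (1.05 log units; beyond the scatter) as a rough estimate. For compound 4 the estimate is 120 nM and the expected range runs from 25 nM to 600 nM as its upper end.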

Compound 4, concentration for 50% growth inhibition: 9600 nM
Estimate against measurement, compound 4: 80-fold (1.90 log units) below; the whole stated range lies below it.
By their numbers in this assay, from the lowest: compound 3; then compound 2; then compound 1; then compound 4.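

In this assay, among the compounds shown here, the nitrogen on the aromatic ring proves far less forgiving than the earlier compounds suggested: acetyl in place of one of its hydrogens gives a 910-fold higher number from compound 3 to compound 4 (2.96 log units; beyond the scatter), the largest step in the set. Set against the hydroxy compound, the change to acetamido gives a 360-fold higher number from compound 2 to compound 4 (2.56 log units; beyond the scatter), so the amino and hydroxy compounds lie fairly close together while the acetamido compound falls far from both, and a modest swap at this place says little about what a larger group will do there. Nothing available explains why this acetyl has so large an effect.

On these data alone, it remains open whether the loss belongs to the acetyl itself or to any group on this nitrogen. A single methyl or a formyl group there could begin to separate those two readings.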